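From carboxy to methoxy on an aromatic ring

This account rests on a few compounds, and the source may have more. Where it says the series, first, only, none or still open, it means among the compounds named here.

Values from a functional assay on K562 cells (Homo sapiens) for inhibition, read by trypan blue exclusion, with a stated time of 72 h (a higher number here means a weaker inhibitor, a lower number a stronger inhibitor), are as follows.
Compound 1 (`COC(=O)Cn1c(=O)c(S(=O)(=O)c2ccc(F)cc2F)cc2cnc(Nc3ccc4[nH]ccc4c3)nc21`) gives 5000 nM as its value.
Compound 2 (`Cn1c(=O)c(S(=O)(=O)c2ccc(C(=O)O)cc2)cc2cnc(Nc3ccc4[nH]ccc4c3)nc21`) gives 5000 nM as its value.

Compound 2 stands level with compound 1, within the usual scatter. Compound 3 (`COc1ccc(S(=O)(=O)c2cc3cnc(Nc4ccc5[nH]ccc5c4)nc3n(C)c2=O)cc1`) has methoxy in place of carboxy on an aromatic carbon, para to a large group (methoxy in place of carboxy on an aromatic carbon). Among the compounds with values here, no measured step shows what this change does. Compound 1 carries no carboxy and gives 5000 nM in this assay so only a moderate move towards a lower number, meaning a stronger inhibitor, is expected. The expected size is a 3.3-fold lower number from compound 2 to compound 3 (0.52 log units; beyond the scatter) in this assay as an estimate. The estimated value for compound 3 is 1500 nM (range 200 nM to 6000 nM).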

Compound 3, half-maximal inhibitory concentration: 300 nM
Compound 3: middle estimate off by 5.0-fold (0.70 log units), on the high side; the measured number falls inside the stated range.
By their numbers in this assay, from the lowest: compound 3; then compounds 1 and 2 (each within the scatter of the next).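

In this assay, the change from 4-carboxyphenyl to 4-methoxyphenyl gives a 17-fold lower number from compound 2 to compound 3 (1.22 log units; beyond the scatter), so the group at this place on the aromatic ring can shift the number well beyond the scatter. This is something the level values of the two earlier compounds could not show. No measurement shown here explains the shift. From the compounds shown here alone, it remains open whether the loss of carboxy or the arrival of methoxy matters more. An amine or a plain hydrogen at this same place would help separate the two.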